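Replacing an Ester Arm with a Free Amine

The compounds below may be only part of what the source reports. "The series", "measured", "known", "first", "only" and "open" are said of these compounds alone.

In a functional assay on HT-1080 cells (Homo sapiens), read by transwell migration, with a stated time of 24 h, tested at 0.1 uM (on this read-out lower numbers stand for a stronger effect and higher numbers for a weaker effect at the one concentration tested), compound 1 `CCCCCC(=O)OCc1ccc2oc(=O)c(C(=O)Oc3cccc(Br)c3)cc2c1` gives 94.3%. Compound 2 `CC(C)C(=O)OCc1ccc2oc(=O)c(C(=O)Oc3cccc(Br)c3)cc2c1` differs from compound 1 only in the alkyl group on the ester carbonyl; in this assay compound 2 gives 54.4%. Within the data shown here, the one measured step, a number 39.9 percentage points lower from compound 1 to compound 2 (beyond the scatter), is large, and on the two numbers available compound 2 stands as the lower of the pair, the stronger of the two in this assay.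

Compound 3 `NCc1ccc2oc(=O)c(C(=O)Oc3cccc(Br)c3)cc2c1` has not yet been measured. It differs from compound 2 by amino in place of (isopropylcarbonyl)oxy on a saturated chain carbon bound to an aromatic carbon. Among the measured compounds shown here, no measured step bears directly on this change: the only step known exchanges one alkyl group for another on the ester carbonyl, whereas here the whole (isopropylcarbonyl)oxy group is gone and an amino group stands in its place. The size and direction of the step are therefore uncertain. As a working guess, compound 3 is expected to lie nearer the weaker end, with a number 20.6 percentage points higher from compound 2 to compound 3 (beyond the scatter), giving an estimated value of 75% in this assay, in a range from 40% to 100%.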

Compound 3, a percentage reported as activity, at one concentration (the size of the read-out at that concentration, not a potency): 88.3%
Estimate against measurement, compound 3: 13.3 percentage points below, and the stated range covers the measured number.
By their numbers in this assay, from the lowest: compound 2; then compounds 3 and 1 (each within the scatter of the next).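

In this assay, taking away the whole (isopropylcarbonyl)oxy group and putting amino on the saturated chain carbon bound to an aromatic carbon gives a number 33.9 percentage points higher from compound 2 to compound 3 (beyond the scatter) and so loses most of what set compound 2 apart. Measured against the pentyl ester, the same exchange gives a number 6 percentage points lower from compound 1 to compound 3 (within the scatter) and leaves the two compounds indistinguishable, although amino has a single heavy atom and no carbonyl. Among these three compounds, then, the lower number belongs to the isopropyl ester alone, which shows that a low number at this place does not come with just any group, and nothing available here explains why.

From the compounds shown here alone, it remains open whether the number of compound 2 depends on the ester link itself or on its isopropyl group, and a hydroxyl group, an acetyl ester or an amide carrying the same isopropyl group on this carbon would help to separate the two. Going by these compounds, it is equally open whether a dimethylamino group would read like amino or move the number in either direction.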